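Moving the Hydroxy Group Around the Phenyl Ring

A few compounds are considered here, and "the series" means these few. Any claim that something is new, unique, unknown or untested is made for them only; others in the source may bear on it.

Compound 1 `COc1cc(/C=C/C(=O)C2=C(/C=C/c3ccc(O)c(OC)c3)NC(=O)NC2c2ccccc2)ccc1O` carries an unsubstituted phenyl group on the saturated ring carbon of its shared core. In a functional assay, with a stated time of 20 min, tested at 50 uM (a lower number here means a weaker effect, a higher number a stronger effect of the compound at the concentration tested), compound 1 gives 40.2%. Compound 2 `COc1cc(/C=C/C(=O)C2=C(/C=C/c3ccc(O)c(OC)c3)NC(=O)NC2c2ccccc2O)ccc1O` differs from it only by a hydroxy in place of hydrogen on an aromatic carbon, and in this assay compound 2 gives 88.9%. That single change produced a number 48.7 percentage points higher from compound 1 to compound 2 (beyond the scatter), and compound 2 therefore stands highest of the two measured compounds, with compound 1 as its nearest and only neighbour.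

Compound 3 `COc1cc(/C=C/C(=O)C2=C(/C=C/c3ccc(O)c(OC)c3)NC(=O)NC2c2ccc(O)cc2)ccc1O` keeps every atom of compound 2 but joins them differently: 4-hydroxyphenyl in place of 2-hydroxyphenyl on a saturated ring carbon. Going by the values given here, the one measured step, from compound 1 to compound 2, shows that adding the hydroxy group raised the read-out strongly, but it says nothing about whether the hydroxy group works equally well in another place on the ring. Among the compounds with values here, no measured pair speaks to such a shift, so the expectation rests on the fact that compound 3 still carries a hydroxy group, unlike compound 1. On that basis compound 3 is expected to give 70%, within a range of 40% to 95%. This estimate means a step of a number 18.9 percentage points lower from compound 2 to compound 3 (beyond the scatter), a modest expected loss with considerable uncertainty.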

Compound 3, a percentage reported as activity, at one concentration (the size of the read-out at that concentration, not a potency): 90.3%
Compound 3: middle estimate off by 20.3 percentage points, on the low side; low and high end bracket the measured number.
By their numbers in this assay, from the lowest: compound 1; then compounds 2 and 3 (each within the scatter of the next).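

In this assay, moving the hydroxy group around the phenyl ring gives a number 1.4 percentage points higher from compound 2 to compound 3 (within the scatter) when 4-hydroxyphenyl replaces 2-hydroxyphenyl on a saturated ring carbon, so the measurements resolve no difference between these two placements. Set against the unsubstituted phenyl group, the 4-hydroxyphenyl group gives a number 50.1 percentage points higher from compound 1 to compound 3 (beyond the scatter) and so shows a large gain of the same kind as the one seen with the 2-hydroxyphenyl group. In compound 2 and compound 3 alike, then, the gain goes with having a hydroxy group on this phenyl ring, and it does not depend on which of these two places the group occupies. Nothing in the data at hand explains why the two groups read alike.

On these data alone, whether the gain needs a hydroxy group at all stays open, since an amine or a carboxylic acid on the same phenyl ring would be needed to show if another group can do the same. These readings also come from a single concentration, so they give the size of the effect there and not a potency, and compound 2 and compound 3 could still separate at lower concentrations.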